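Swapping fluoro for methoxy on the anilino ring

A few compounds are considered here, and "the series" means these few. Any claim that something is new, unique, unknown or untested is made for them only; others in the source may bear on it.

Compound 3 `COc1cc(-c2nn(-c3ccccc3)cc2C(=O)/C=C\Nc2ccc(F)cc2)cc(OC)c1OC` is one of three related compounds tested in a functional assay on PC-3 cells (Homo sapiens) for antiproliferative activity, read by MTT assay, with a stated time of 48 h; a lower number here means a stronger inhibitor, a higher number a weaker inhibitor. In this assay compound 3 gives 7700 nM, the lowest of the three numbers. Compound 1 `O=C(/C=C\Nc1ccc(F)cc1)c1cn(-c2ccccc2)nc1-c1ccccc1` gives 7980 nM, which lies within the scatter of compound 3, so the two cannot be separated. Compound 2 `COc1ccc(-c2nn(-c3ccccc3)cc2C(=O)/C=C\Nc2cc(OC)c(OC)c(OC)c2)cc1` gives 18900 nM, a number beyond the scatter above compound 3.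

Compound 4 `COc1ccc(N/C=C\C(=O)c2cn(-c3ccccc3)nc2-c2cc(OC)c(OC)c(OC)c2)cc1` has not yet been measured. It differs from compound 3 in one place: methoxy in place of fluoro on an aromatic carbon. In short, a methoxy sits in place of fluoro on an aromatic carbon. Within the data shown here, no measured pair in this set shows this exact swap, so the size of the step can only be estimated. Because compound 1 gives 7980 nM and compound 3 gives 7700 nM, two numbers within the scatter of each other despite a larger difference elsewhere, the expected step from compound 3 to compound 4 is small, a 1.2-fold higher number from compound 3 to compound 4 (0.07 log units; within the scatter), with no clear direction. The expected value for compound 4 is therefore 9000 nM, within a range of 3500 nM to 25000 nM.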

Compound 4, half-maximal inhibitory concentration: 9600 nM
Compound 4: middle estimate off by 1.1-fold (0.03 log units), on the low side; measured number inside the range.
By their numbers in this assay, from the lowest: compounds 3, 1, 4 and 2 (each within the scatter of the next, the first and the last beyond it).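

In this assay, among these compounds, the change from (4-fluorophenyl)amino to (4-methoxyphenyl)amino gives the first comparison in this set that differs in only one place, and it reads a 1.2-fold higher number from compound 3 to compound 4 (0.10 log units; within the scatter). Methoxy brings 2 heavy atoms and 1 hydrogen-bond acceptor where fluoro has 1 heavy atom and 0 hydrogen-bond acceptors, yet this assay cannot separate the two groups at this position. No measurement here explains why they read alike.

A single pair says nothing about how the position would respond to a very different group, such as a dimethylamino group, a carboxylic acid or a longer butoxy chain. It also leaves open whether the same swap would behave alike on the other ring substitution patterns, since compound 2 differs from these compounds in more than one place.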